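The compounds below may be only part of what the source reports. "The series", "measured", "known", "first", "only" and "open" are said of these compounds alone.

Compound 1 `O=C(O)/C(S)=C/c1c[nH]c2ccc(F)cc12` gives 800 nM in an assay on isolated protein for inhibition of Calpain-1 catalytic subunit (Sus scrofa), read by FRET; a lower number here means a stronger inhibitor, a higher number a weaker inhibitor.
Compound 2 `O=C(O)/C(S)=C/c1c[nH]c2c(F)cccc12` gives 120 nM in this assay.
Compound 3 `O=C(O)/C(S)=C/c1c[nH]c2cc(F)ccc12` gives 10 nM in this assay.

Among these three, compound 1 carries the highest number and is the weakest inhibitor of the set. Compound 2 sits nearest to it and compound 3 lies furthest from it, and both of those gaps go beyond the usual scatter of repeated measurements. All three share the same core and carry a single fluoro on it. Compound 4 `O=C(O)/C(S)=C/c1c[nH]c2ccc(Br)cc12` differs from compound 1 in one respect: bromo in place of fluoro on an aromatic carbon. Among the measured compounds shown here, no measured pair shows what this exchange of one halogen for another does on this core, so the expectation rests on compound 1 alone and is held loosely. A modest step in this assay is expected, towards a lower number, one that may not clear the scatter. Compound 4 is therefore estimated at 400 nM, expected to fall between 100 nM and 1500 nM. The expected step is a 2.0-fold lower number from compound 1 to compound 4 (0.30 log units; within the scatter).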

Compound 4, half-maximal inhibitory concentration: 6 nM
Beside the measured number, compound 4's estimate is 67-fold (1.82 log units) above it, and the stated range ends above it.
By their numbers in this assay, from the lowest: compounds 4 and 3 (each within the scatter of the next); then compound 2; then compound 1.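

Exchanging fluoro for bromo on this aromatic carbon gives a 130-fold lower number from compound 1 to compound 4 (2.12 log units; beyond the scatter) in this assay, so one halogen atom at this position can separate a weak inhibitor from a strong one. The earlier compounds shown here all carried fluoro, so they could show nothing about changing the halogen itself; this pair shows that its identity matters a great deal on the shared core. Nothing available here accounts for the size of this step.

From the compounds shown here alone, whether chloro or iodo on this same carbon would land nearer compound 1 or nearer compound 4 remains open, as does whether a group that is not a halogen, such as methyl or methoxy, could serve here. Also open, going by these compounds, is what bromo would do on the carbons that bear fluoro in compound 2 and compound 3.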